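Trimethoxyphenyl Variant of a Thiazolidine Carboxamide Series

A few compounds are considered here, and "the series" means these few. Any claim that something is new, unique, unknown or untested is made for them only; others in the source may bear on it.

Compound 1 `CCCCCCCCCCCCCCCCCCNC(=O)[C@@H]1CSC(c2cccc(O)c2)N1`: 4000 nM
Compound 2 `CCCCCCCCCCCCCCCCCCNC(=O)[C@@H]1CSC(c2ccc(OC)cc2)N1`: 19600 nM

In a functional assay on TSU-Pr1 cells (Homo sapiens) for antiproliferative activity, read by sulforhodamine B assay (a lower number here means a stronger inhibitor, a higher number a weaker inhibitor), compound 2 gives the highest of the two numbers, with compound 1 nearest at 4000 nM. Compound 3 `CCCCCCCCCCCCCCCCCCNC(=O)[C@@H]1CSC(c2cc(OC)c(OC)c(OC)c2)N1` carries 3,4,5-trimethoxyphenyl in place of 4-methoxyphenyl on a saturated ring carbon. Going by the values given here, the only measured step, a 4.9-fold higher number from compound 1 to compound 2 (0.69 log units; beyond the scatter), swaps one ring substituent for another and does not show what two further methoxy groups do, so no step bears directly on this change. The expected outcome is therefore a step of uncertain direction, a 2.0-fold lower number from compound 2 to compound 3 (0.29 log units; within the scatter), and compound 3 is estimated at 10000 nM, between 2500 nM and 40000 nM.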

Compound 3, half-maximal inhibitory concentration: 2400 nM
For compound 3 the middle estimate is 4.2-fold (0.62 log units) above the measured one; measured number below the stated range.
By their numbers in this assay, from the lowest: compounds 3 and 1 (each within the scatter of the next); then compound 2.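

In this assay, going by these compounds alone, the saturated ring carbon proves sensitive to which aryl group it carries: 3,4,5-trimethoxyphenyl in place of 4-methoxyphenyl gives an 8.2-fold lower number from compound 2 to compound 3 (0.91 log units; beyond the scatter) and so recovers what the single methoxy group had lost. Set against 3-hydroxyphenyl, the same group gives a 1.7-fold lower number from compound 1 to compound 3 (0.22 log units; within the scatter) and thus no order between the two. No measured evidence explains this change.

Left open is whether a dimethoxyphenyl group would do the same, and how an amine on the aromatic ring would read.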